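Methoxy on the Anilino Ring of a Thiazole Amide

The source may hold more compounds than are shown below. What is called first, only, known or untested is meant among the compounds shown, and "the series" means these compounds.

Of the compounds shown here, two have been measured in a functional assay on SK-MEL-5 cells (Homo sapiens) for antiproliferative activity, read by sulforhodamine B assay, with a stated time of 48 h; on this read-out higher numbers stand for weaker inhibition of growth and lower numbers for stronger inhibition of growth. Compound 1, `Cc1nc(SCC(=O)Nc2nc(-c3ccc(Cl)cc3)cs2)n(Nc2ccccc2)c1C`, gives 2240 nM in this assay. Compound 2, `Cc1ccc(Nn2c(SCC(=O)Nc3nc(-c4ccccc4)cs3)nc(C)c2C)cc1`, gives 2000 nM in this assay. For the measured compounds named here, compound 1 carries the higher of the two numbers, yet its only neighbour, compound 2, sits within the scatter of it, so no order between the two can be read from these figures.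

Compound 3, `COc1ccc(Nn2c(SCC(=O)Nc3nc(-c4ccc(Cl)cc4)cs3)nc(C)c2C)cc1`, has not yet been measured. It differs from compound 1 in one place: methoxy in place of hydrogen on an aromatic carbon. In words, a methoxy takes the place of a hydrogen on an aromatic carbon of a six-membered aromatic ring of carbon only, para to a large group. Going by the values given here, no pair of measured compounds isolates this change, so its size is not known from the data. Compound 2 carries a different substituent on that ring and lacks the chlorine of compound 1, and still its value stays within the scatter of compound 1, which hints that changes on this ring move the number little. Compound 3 is therefore expected to give about 2000 nM in this assay, within a range from 900 nM to 4500 nM. The step of a 1.1-fold lower number from compound 1 to compound 3 (0.05 log units; within the scatter) is expected to stay within the scatter, in no clear direction.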

Compound 3, concentration for 50% growth inhibition: 1410 nM
Beside the measured number, compound 3's estimate is 1.4-fold (0.15 log units) above it; measured number inside the range.
By their numbers in this assay, from the lowest: compounds 3, 2 and 1 (each within the scatter of the next).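

In this assay, for the compounds shown here, the pair of compound 1 and compound 3 is the first to isolate this change, phenyl to 4-methoxyphenyl on the anilino part of the core, and it gives a 1.6-fold lower number from compound 1 to compound 3 (0.20 log units; within the scatter) without leaving the scatter. The data therefore now show directly, and no longer only by a hint from a compound that differs in more than one place, that this aromatic carbon can carry a methoxy in place of hydrogen with no readable shift in growth inhibition. No measurement shown here offers an explanation for this result.

The compounds shown leave open whether a different group at this same place, such as a hydroxy, an amine or a carboxylic acid, or a longer chain on the oxygen, such as ethoxy, would move the number beyond the scatter. They also leave open what the chlorine of compound 1 contributes on its own, as no pair shown isolates that chlorine.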